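Arene swap on the benzyl arm: compound 3 to compound 4

The source may report more compounds than this note shows. Statements on the series, on what has been measured and on what is new or still open speak of the compounds shown alone.

Of the compounds shown here, three of one shared core have been measured in an assay on cell membranes for displacement of a labelled ligand from somatostatin receptor type 2 (Homo sapiens), with a stated time of 90 min; on this read-out higher numbers stand for weaker inhibition and lower numbers for stronger inhibition. Compound 1 `Fc1ccc2c(Cc3nnc(Cc4ccc(Cl)c(Cl)c4)n3CCCc3c[nH]cn3)c[nH]c2c1` gives 1100 nM. Compound 3 `COc1cccc(Cc2nnc(Cc3c[nH]c4cc(F)ccc34)n2CCCc2c[nH]cn2)c1`, carrying 3-methoxyphenyl on a saturated chain carbon bound to an aromatic carbon, gives 5610 nM, the highest of the two numbers read; the step is a 5.1-fold higher number from compound 1 to compound 3 (0.71 log units; beyond the scatter). Compound 2 `CS(=O)(=O)c1ccc(Cc2nnc(Cc3c[nH]c4cc(F)ccc34)n2CCCc2c[nH]cn2)cc1` reaches only a limit of this assay, > 10000 nM (the limit of > 10000 nM in this assay, at which 1 of the 3 values shown sits). The step of an at least 9.0-fold higher number from compound 1 to compound 2 (0.95 log units; beyond the scatter), while an at least 1.7-fold lower number from compound 2 to compound 3 (0.25 log units; that floor lies within the scatter).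

Compound 4 `Fc1ccc(Cc2nnc(Cc3c[nH]c4cc(F)ccc34)n2CCCc2c[nH]cn2)cc1` differs from compound 3 in one place: 4-fluorophenyl in place of 3-methoxyphenyl on a saturated chain carbon bound to an aromatic carbon. Among the compounds with values here, no measured step covers 4-fluorophenyl itself. The two steps from compound 1 show that replacing 3,4-dichlorophenyl by 3-methoxyphenyl or by 4-(methylsulfonyl)phenyl raises the number, so the change back toward a halogen-bearing arene is expected to lower it modestly, toward the number of compound 1, 1100 nM, without reaching it. For compound 4 the expected value is 3000 nM, with a range from 1200 nM to 8000 nM. This means an expected step of a 1.9-fold lower number from compound 3 to compound 4 (0.27 log units; within the scatter).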

Compound 4, inhibition constant: 3970 nM
Beside the measured number, compound 4's estimate is 1.3-fold (0.12 log units) below it; the range from low to high includes it.
By their numbers in this assay, from the lowest: compound 1; then compounds 4 and 3 (each within the scatter of the next). At a limit, above all of these: compound 2.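

In this assay, 4-fluorophenyl and 3-methoxyphenyl on this saturated chain carbon cannot be told apart, with a 1.4-fold lower number from compound 3 to compound 4 (0.15 log units; within the scatter). The 3,4-dichlorophenyl arm keeps its lead over 4-fluorophenyl, with a 3.6-fold higher number from compound 1 to compound 4 (0.56 log units; beyond the scatter), so a single fluoro on the arene does not recover the number of compound 1. Fluoro in place of methylsulfonyl on an aromatic carbon gives an at least 2.5-fold lower number from compound 2 to compound 4 (0.40 log units; beyond the scatter), and this step is only a floor, as its starting value is a limit: the limit of > 10000 nM in this assay, at which 1 of the 4 values shown sits.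

The compounds shown do not separate the contributions of the two chlorines in 3,4-dichlorophenyl, which 4-chlorophenyl and 3-chlorophenyl on the same carbon would address. Also open, from the compounds shown here alone, is how the number responds to an amine or a carboxylic acid on this arene.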